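Growth inhibition notes on a small triaryl series

This account rests on a few compounds, and the source may have more. Where it says the series, first, only, none or still open, it means among the compounds named here.

Measured so far:
compound 1 `c1ccc(-c2nc3sc(-c4ccccc4)cn3n2)cc1` — 63%
compound 2 `COc1ccc(-c2nc3sc(-c4ccc(Cl)cc4)cn3n2)cc1` — 45.1%
compound 3 `COc1cc(-c2nc3sc(-c4ccccc4)cn3n2)cc(OC)c1OC` — 55%

In a functional assay on T47D cells (Homo sapiens) for inhibition, read by sulforhodamine B assay, with a stated time of 48 h, tested at 10 uM (on this read-out lower numbers stand for less inhibition of growth and higher numbers for more inhibition of growth at the one concentration tested), compound 2 gives the lowest number of the three. Against compound 3 the gap is within the usual scatter; against compound 1 it is beyond it, so compound 2 trails compound 1 on this read-out.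

Compound 4 `Clc1ccc(-c2cn3nc(-c4ccccc4)nc3s2)cc1` has not yet been measured. Compared with compound 2 the change is hydrogen in place of methoxy on an aromatic carbon.

Among the compounds with values here, no step between measured compounds matches this change. Compound 1, which carries no methoxy, gives 63%, so a small rise is expected. For compound 4 the estimate is 52% with a range of 36% to 68%. The expected step of a number 6.9 percentage points higher from compound 2 to compound 4 (within the scatter) may well stay within the scatter.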

Compound 4, percent growth inhibition at one concentration: 74%
Estimate against measurement, compound 4: 22 percentage points below; the whole stated range lies below it.
By their numbers in this assay, from the lowest: compounds 2, 3 and 1 (each within the scatter of the next, the first and the last beyond it); then compound 4.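

Hydrogen in place of methoxy on the aromatic carbon para to a large group, with the chloro kept, gives a number 28.9 percentage points higher from compound 2 to compound 4 (beyond the scatter) as the first readable step at this place, and methoxy there goes with less growth inhibition. Chloro in place of hydrogen on an aromatic carbon, with no methoxy present, gives a number 11 percentage points higher from compound 1 to compound 4 (beyond the scatter) as a second single change that also ends at compound 4. No measurement at hand accounts for either step.

On these data alone, whether the chloro step holds with methoxy present remains open. So does the outcome with an amine or a carboxylic acid at the methoxy place.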